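Swapping a pyridinyl for a cyclohexyl on the piperazine nitrogen

A few compounds are considered here, and "the series" means these few. Any claim that something is new, unique, unknown or untested is made for them only; others in the source may bear on it.

The series shares one core, seen in compound 3 `O=C(CN1CCN(c2ccccn2)CC1)Nc1nc2c(s1)CCCC2`. In a physicochemical assay for lipophilicity, in phosphate buffer, measured as octanol-water partition, at pH 7.4 (a higher number here means a more lipophilic compound, a lower number a more polar compound), compound 3 gives 3.9, the lowest of the two numbers in hand; its nearest neighbour, compound 1 `O=C(CN1CCN(c2ccc(F)cc2)CC1)Nc1nc2c(s1)CCCC2`, gives 4.5 in this assay. Compound 2 `O=C(CN1CCN(c2cccc(F)c2)CC1)Nc1nc2c(s1)CCCC2` gives "not determined" (no result reported) in this assay, so no number is in hand for it. For the measured compounds named here, the one measured step, a number 0.60 log units lower from compound 1 to compound 3 (beyond the scatter), is modest and lies beyond the scatter. Compound 4 `O=C(CN1CCN(C2CCCCC2)CC1)Nc1nc2c(s1)CCCC2` differs from compound 3 in one place: cyclohexyl in place of pyridin-2-yl on an amine nitrogen in a ring. Going by the values given here, no measured step exchanges an aromatic ring for a saturated one, so the expectation rests loosely on the direction of that single step. Compound 4 is expected to give 4.2 in this assay, within 3.4 to 5, an estimated step of a number 0.30 log units higher from compound 3 to compound 4 (within the scatter).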

Compound 4, distribution coefficient: 3
Beside the measured number, compound 4's estimate is 1.20 log units above it, outside the stated range (below it).
By their numbers in this assay, from the lowest: compound 4; then compound 3; then compound 1.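

In this assay, putting a non-aromatic ring on this amine nitrogen in a ring gives a number 0.90 log units lower from compound 3 to compound 4 (beyond the scatter), and the same group in place of 4-fluorophenyl gives a number 1.50 log units lower from compound 1 to compound 4 (beyond the scatter). Compound 4 therefore stands lowest of the three numbered compounds, so among these groups the aromatic rings do not give the lowest number. Nothing in hand accounts for this drop. The compounds shown leave open whether an open carbon chain, or a cyclohexyl ring carrying an amine, on this nitrogen would also fall below compound 3.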